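A fluoro-for-methoxy change in a cytotoxicity screen

The compounds below may be only part of what the source reports. "The series", "measured", "known", "first", "only" and "open" are said of these compounds alone.

Compound 1, `CCS(=O)(=O)Nc1ccc(NC(=O)c2ccc(Cl)cc2)cc1OC`: in an ADME assay on HEK293 cells (Homo sapiens) for cytotoxicity, read by MTT assay, with a stated time of 48 h (on this read-out lower numbers stand for stronger inhibition and higher numbers for weaker inhibition), compound 1 gives > 250000 nM, which is a limit of the assay.
Compound 2, `CCS(=O)(=O)Nc1ccc(NC(=O)c2ccc(C#N)cc2)cc1OC`: in this assay compound 2 gives > 250000 nM, which is a limit of the assay.
Compound 3, `COc1cc(NC(=O)c2ccc(C#N)cc2)ccc1NS(=O)(=O)C(F)(F)F`: in this assay compound 3 gives > 250000 nM, which is a limit of the assay.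

Compound 2 thus stands at the limit of this assay, and the two further values shown are limits as well (the limit of > 250000 nM in this assay, at which 3 of the 3 values shown sit). Cyano in place of chloro on an aromatic carbon gave a step that the two limits leave unreadable from compound 1 to compound 2. Trifluoromethyl in place of ethyl on a sulfonyl sulfur gave a step that the two limits leave unreadable from compound 2 to compound 3. Compound 4, `CCS(=O)(=O)Nc1ccc(NC(=O)c2ccc(C#N)cc2)cc1F`, differs from compound 2 by fluoro in place of methoxy on an aromatic carbon. Neither measured step yields a readable size that could guide this change, and every value shown sits at the same limit (the limit of > 250000 nM in this assay, at which 3 of the 3 values shown sit). The step expected in this assay is therefore a step that the limit leaves unreadable from compound 2 to compound 4, with nothing beyond the scatter readable from the numbers at hand. Compound 4 is expected to give about 300000 nM in this assay, within a range from 100000 nM to 900000 nM, and most probably to be reported again only as a limit.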

Compound 4, half-maximal inhibitory concentration: 26400 nM
Compound 4: the middle estimate sits 11-fold (1.06 log units) above what was measured; measured number below the stated range.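

In this assay, fluoro in place of methoxy on an aromatic carbon, ortho to the (ethylsulfonyl)amino group, gave an at least 9.4-fold lower number from compound 2 to compound 4 (0.97 log units; beyond the scatter). This position is thus the only place among the changes shown where a step can be read, and the change moves the read-out towards stronger inhibition. The swaps of cyano for chloro and of trifluoromethyl for ethyl could not be read, and the other values remain limits: the limit of > 250000 nM in this assay, at which 3 of the 4 values shown sit.

As far as these compounds go, the full size of the step stays open, as does whether losing methoxy or gaining fluoro drives it, and a hydroxyl group, an amine or a plain hydrogen at this position could help to separate the two. From the compounds shown here alone, it is also open whether the same change would carry over to the chloro-bearing core of compound 1 or the trifluoromethyl-bearing core of compound 3.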